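Replacing the amino group of compound 2 with ethyl

A few compounds are considered here, and "the series" means these few. Any claim that something is new, unique, unknown or untested is made for them only; others in the source may bear on it.

Within the data shown here, in a functional assay on MDA-MB-468 cells (Homo sapiens) for antiproliferative activity, read by WST assay, with a stated time of 3 days (a higher number here means a weaker inhibitor, a lower number a stronger inhibitor), compound 2 `Nc1c(F)c(=O)[nH]c(=O)n1[C@@H]1O[C@H](CO)[C@@H](O)[C@H]1O` gives 2600 nM, the only true number available so far. Compound 1 `O=c1[nH]c(=O)n([C@@H]2O[C@H](CO)[C@@H](O)[C@H]2O)c(I)c1F`, built on the same core, reads > 50000 nM, and this is a limit of the assay, not a number.

Compound 3 `CCc1c(F)c(=O)[nH]c(=O)n1[C@@H]1O[C@H](CO)[C@@H](O)[C@H]1O` differs from compound 2 at one place, with ethyl in place of amino on an aromatic carbon, next to the ring nitrogen: ethyl in place of amino on an aromatic carbon.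

Among the measured compounds shown here, the only measured step that bears on this change is an at least 19-fold lower number from compound 1 to compound 2 (1.28 log units; beyond the scatter), which is large and beyond the scatter, and which came with amino in place of iodo on an aromatic carbon. Losing the amino group is therefore expected to push the number back up in this assay, towards weaker inhibition. One step is thin evidence, and ethyl has not been measured here, so the size of the move is uncertain and a result that is only a limit is quite possible. The expected move, as estimated, is an 8.5-fold higher number from compound 2 to compound 3 (0.93 log units; beyond the scatter). For compound 3 the estimate is 22000 nM, with an expected range of 6000 nM to 50000 nM.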

Compound 3, half-maximal inhibitory concentration: 5300 nM
Compound 3: middle estimate off by 4.2-fold (0.62 log units), on the high side; the whole stated range lies above it.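

In this assay, the step of a 2.0-fold higher number from compound 2 to compound 3 (0.31 log units; beyond the scatter) is beyond the scatter but only modest, so this position does not depend on the amino group alone: ethyl, which carries no hydrogen-bond donor, stays close to it. The comparison with iodo makes the same point from the other side, with an at least 9.4-fold lower number from compound 1 to compound 3 (0.97 log units; beyond the scatter) showing that ethyl, like amino, stands well clear of the iodo compound, so the large gain seen earlier is not unique to amino. The true size of both steps from iodo remains unknown, since compound 1 is recorded only as a limit of the assay and not as a number: the limit of > 50000 nM in this assay, at which 1 of the 3 values shown sits.

The compounds shown leave open how far this tolerance extends, for instance whether a methyl, a longer chain such as propyl, a hydroxyl or a carboxylic acid on this carbon would stay near amino and ethyl or fall back towards iodo. Among these compounds, with only three groups at one position and a single cell assay, they also cannot explain why iodo differs so strongly from the other two.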